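Chloro on the phenyl of compound 1: expected effect

This account rests on a few compounds, and the source may have more. Where it says the series, first, only, none or still open, it means among the compounds named here.

Measured so far:
compound 1 `CC(=O)NN1C(=O)C(Cc2ccccc2)=NN2C1=NN(C(C)=O)C2(C)c1ccccc1` gives 13.2 nM
compound 2 `COc1ccc(C2N(C(C)=O)N=C3N2N=C(Cc2ccccc2)C(=O)N3N(C(C)=O)C(C)=O)cc1` gives 9.71 nM

Compound 1 has the higher of the two numbers in an assay on microsomes from liver for inhibition of cytochrome P450 1A1 (Rattus norvegicus), read by fluorescence, with a stated time of 10 min (on this read-out higher numbers stand for weaker inhibition and lower numbers for stronger inhibition), and compound 2 sits within the scatter of it, so neither can be said to bind more strongly.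

Compound 3 `CC(=O)NN1C(=O)C(Cc2ccccc2)=NN2C1=NN(C(C)=O)C2(C)c1ccc(Cl)cc1` is not yet measured. Against compound 1 it carries one change: chloro in place of hydrogen on an aromatic carbon. Among the compounds with values here, no step of this kind stands, so there is nothing to scale from. The expected step of a 1.1-fold lower number from compound 1 to compound 3 (0.04 log units; within the scatter) is none beyond the scatter, in either direction. Compound 3 is estimated at 12 nM, with a range from 4 nM to 35 nM.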

Compound 3, half-maximal inhibitory concentration: 5.69 nM
The estimate for compound 3 lay 2.1-fold (0.32 log units) above the measured number, and the stated range covers the measured number.
By their numbers in this assay, from the lowest: compounds 3, 2 and 1 (each within the scatter of the next, the first and the last beyond it).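

In this assay, within the data shown here, phenyl to 4-chlorophenyl gives a 2.3-fold lower number from compound 1 to compound 3 (0.37 log units; beyond the scatter) and so provides the first single-place comparison. This position, on the aromatic ring and para to a large group, therefore responds to substitution, and chloro in place of hydrogen goes with stronger inhibition. No measurement shown here bears on the cause of this step.

From the compounds shown here alone, whether fluoro, methyl or an amine at the same place would shift the number in the same direction stays open. So does whether chloro elsewhere on this ring would do so.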